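Dropping the chloro group from compound 1

The compounds below may be only part of what the source reports. "The series", "measured", "known", "first", "only" and "open" are said of these compounds alone.

In a functional assay on IMR-32 cells (Homo sapiens) for antiproliferative activity, read by sulforhodamine B assay, with a stated time of 48 h (on this read-out lower numbers stand for stronger inhibition and higher numbers for weaker inhibition), compound 1 (`COc1ccc(C[C@@H](O)/C=C/C=C/C(=O)NCc2ccc(Cl)cc2)cc1OC`) gives 15700 nM and compound 2 (`COc1ccc(C[C@@H](O)/C=C/C=C/C(=O)N2CCN(C(c3ccccc3)c3ccccc3)CC2)cc1OC`) gives 11900 nM. For the measured compounds named here, these two numbers lie within the scatter of each other, so compound 1 does not stand apart from the only other measured compound. Compound 3 (`COc1ccc(C[C@@H](O)/C=C/C=C/C(=O)NCc2ccccc2)cc1OC`) carries hydrogen in place of chloro on an aromatic carbon, para to a large group, which turns 4-chlorobenzyl into benzyl (hydrogen in place of chloro on an aromatic carbon). Going by the values given here, no measured pair shows this change on its own, so the data give no size for it. In this assay no step beyond the scatter is expected, and neither direction is favoured. The estimated size is a 1.1-fold higher number from compound 1 to compound 3 (0.03 log units; within the scatter) and so stays within the scatter. The expected value for compound 3 is 17000 nM with an estimated range from 8000 nM to 36000 nM on this read-out.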

Compound 3, half-maximal inhibitory concentration: 16600 nM
Beside the measured number, compound 3's estimate is 1.0-fold (0.01 log units) above it; the range from low to high includes it.
By their numbers in this assay, from the lowest: compounds 2, 1 and 3 (each within the scatter of the next).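

Swapping chloro for hydrogen on the aromatic carbon para to a large group gives, in this assay, a 1.1-fold higher number from compound 1 to compound 3 (0.02 log units; within the scatter). For the compounds shown here, this is the first comparison in which only one place differs, and it shows that 4-chlorobenzyl and benzyl cannot be told apart on this read-out when attached to the core of compound 1. No measurement shown here explains this outcome.

The compounds shown leave open whether another group at this position, such as methoxy, an amine or a carboxylic acid, would give a step beyond the scatter. They also leave open whether a longer chain, such as phenethyl in place of benzyl, would change the number in this assay.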